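Pyrrolidin-1-yl in Place of Cyclohexylamino in a Weak Pair

This account rests on a few compounds, and the source may have more. Where it says the series, first, only, none or still open, it means among the compounds named here.

Among the measured compounds shown here, in a functional assay on HL-60 cells (Homo sapiens) for cytotoxicity, read by MTT assay, with a stated time of 48 h (on this read-out higher numbers stand for weaker inhibition and lower numbers for stronger inhibition), compound 2 `O=C(Nc1cc(C(F)(F)F)ccc1NC1CCCCC1)c1ccncc1` gives 59200 nM, the only number in this set. Compound 1 `O=C(Nc1cc(C(F)(F)F)ccc1N1CCCC1)c1cccnc1Cl` was reported in this assay as "not active" (no number reported), without a number, so compound 2 stands alone and cannot be ranked against it. Compound 3 `O=C(Nc1cc(C(F)(F)F)ccc1N1CCCC1)c1ccncc1` differs from compound 2 by pyrrolidin-1-yl in place of cyclohexylamino on an aromatic carbon. For the measured compounds named here, no measured step covers this change; the expectation rests on compound 2 at 59200 nM and on the inactive compound 1, which carries the same pyrrolidin-1-yl group. A step within the scatter, leaning toward weaker inhibition, is expected, a 1.4-fold higher number from compound 2 to compound 3 (0.16 log units; within the scatter). Compound 3 is estimated at 85000 nM, within 30000 nM to 250000 nM. For compound 1 only "not active" (no number reported) was reported, and the same may well happen for compound 3.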

Compound 3, half-maximal inhibitory concentration: "not active" (no number reported)
Nothing numeric was reported for compound 3; the estimate stays without a comparison.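

Among the compounds shown here, compound 3, like compound 1, was reported without a number, so no step from compound 2 to compound 3 can be read. The compounds shown leave open how large the effect of pyrrolidin-1-yl in place of cyclohexylamino is. Nothing shown here bears on this result.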